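The source may report more compounds than this note shows. Statements on the series, on what has been measured and on what is new or still open speak of the compounds shown alone.

Compound 1 `COc1ccc(F)cc1CNCCCNc1ccnc2cc(C3CCCCC3)ccc12` gives 9.47 in a physicochemical assay for acid dissociation.
Compound 2 `c1coc(CNCCCNc2ccnc3cc(C4CCCCC4)ccc23)c1` gives 9.47.
Compound 3 `CCC(CC)c1ccc2c(NCCCNCc3ccco3)ccnc2c1` gives 9.47.

Compound 1 stands level with compounds 2 and 3 at the digits shown. The two measured steps, no change at the digits printed from compound 1 to compound 2 (within the scatter) and no change at the digits printed from compound 2 to compound 3 (within the scatter), both stay within the scatter, one at the amine end of the chain and one on an aromatic carbon of the shared core. Compound 4 `COc1ccc(F)cc1CNCCCNc1ccnc2cc(Oc3ccccc3)ccc12` differs from compound 1 by phenoxy in place of cyclohexyl on an aromatic carbon. This change sits on the same aromatic carbon as the second measured step, which moved nothing, and the first step shows that the other end is equally insensitive. A step from compound 1 to compound 4 of no size beyond the scatter is therefore expected, no change at the digits printed from compound 1 to compound 4 (within the scatter). Compound 4 is expected at 9.47, between 9.2 and 9.75.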

Compound 4, acid dissociation constant: 9.28
Compound 4: middle estimate off by 0.19 log units, on the high side; low and high end bracket the measured number.
By their numbers in this assay, from the lowest: compounds 4, 1, 2 and 3 (each within the scatter of the next).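

In this assay, phenoxy in place of cyclohexyl on the aromatic carbon gives a number 0.19 log units lower from compound 1 to compound 4 (within the scatter) and so stays within the scatter. The earlier compounds shown here carried only cyclohexyl or pentan-3-yl at this position, so the insensitivity now also covers a group with an aromatic ring, an oxygen and a hydrogen-bond acceptor. No measurement available here bears on why the number holds so steady. Still open, on these data alone, is whether an amine or a carboxylic acid on this aromatic carbon would move the number beyond the scatter.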